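Amide at the ring position: working notes on the series

The source may hold more compounds than are shown below. What is called first, only, known or untested is meant among the compounds shown, and "the series" means these compounds.

Measured so far:
- compound 1 `CCOC(=O)C(=O)Nc1cc(N2CCc3ccccc3C2)cc(C)n1`; in an assay on brain for binding affinity to Adrenergic receptor alpha-1 (Rattus norvegicus), read by radioligand binding (a higher number here means a weaker inhibitor, a lower number a stronger inhibitor), compound 1 gives 12000 nM
- compound 2 `Cc1cc(N2CCc3ccccc3C2)ccn1`; in this assay compound 2 gives 5700 nM

Among the compounds with values here, compound 2 stands lowest of the two numbers; the only step to it is a 2.1-fold lower number from compound 1 to compound 2 (0.32 log units; beyond the scatter), a modest step. Compound 3 `Cc1cc(N2CCc3ccccc3C2)cc(NC(=O)CO)n1` carries ((hydroxymethyl)carbonyl)amino in place of hydrogen on an aromatic carbon. Within the data shown here, the step from compound 1 to compound 2 is the one measured step that bears on this change: it removed an amide at the same position and lowered the number modestly. Putting a smaller amide back there, a rise toward the number of compound 1 is expected: a 1.6-fold higher number from compound 2 to compound 3 (0.20 log units; within the scatter). For compound 3 the estimate is 9000 nM, with a range of 4000 nM to 20000 nM.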

Compound 3, inhibition constant: 20000 nM
Compound 3: middle estimate off by 2.2-fold (0.35 log units), on the low side, and the stated range covers the measured number.
By their numbers in this assay, from the lowest: compound 2; then compounds 1 and 3 (each within the scatter of the next).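

At the aromatic carbon next to the ring nitrogen, ((hydroxymethyl)carbonyl)amino in place of hydrogen gives a 3.5-fold higher number from compound 2 to compound 3 (0.55 log units; beyond the scatter) in this assay and so both amides shown print higher numbers than the hydrogen. At the far end of the amide, hydroxymethyl in place of ethoxycarbonyl gives a 1.7-fold higher number from compound 1 to compound 3 (0.22 log units; within the scatter) and so this change does not separate the two amides. No data on the cause of either step are at hand.

Still open, from the compounds shown here alone, is how a plain amine or a carboxylic acid at this position would compare with hydrogen. Going by these compounds, an amide with a longer chain also remains open.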